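Benzyl to Methyl on Selenium: an Expected Potency Gain

The source may hold more compounds than are shown below. What is called first, only, known or untested is meant among the compounds shown, and "the series" means these compounds.

Measured compounds:
Compound 1 `C[Se]/C(=N\C(=O)c1cccs1)NC(=O)c1cccs1` gives 1500 nM.
Compound 2 `O=C(/N=C(/NC(=O)c1ccno1)[Se]Cc1ccccc1)c1ccno1` gives 58900 nM.
Compound 3 `O=C(/N=C(/NC(=O)c1cccs1)[Se]Cc1ccccc1)c1cccs1` gives 58100 nM.

In a functional assay on HepG2 cells (Homo sapiens) for cytotoxicity, read by MTT assay, with a stated time of 72 h (on this read-out lower numbers stand for stronger inhibition of growth and higher numbers for weaker inhibition of growth), compound 3 and compound 2 stand close together; how their two cores differ is not broken down here. Compound 1 carries the change (hydrogen in place of phenyl on a saturated chain carbon bound to a selenium atom). The step between them is a 39-fold lower number from compound 3 to compound 1 (1.59 log units; beyond the scatter).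

Compound 4 `C[Se]/C(=N\C(=O)c1ccno1)NC(=O)c1ccno1` is not yet measured. It differs from compound 2 by hydrogen in place of phenyl on a saturated chain carbon bound to a selenium atom, the same change that separates compound 3 from compound 1, made on the core of compound 2. Among the measured compounds shown here, because compound 2 gives 58900 nM and the earlier step was a 39-fold lower number from compound 3 to compound 1 (1.59 log units; beyond the scatter), a step of similar size is expected, a 29-fold lower number from compound 2 to compound 4 (1.47 log units; beyond the scatter), though only one prior example supports it. Compound 4 is therefore estimated at 2000 nM, with a range from 500 nM to 8000 nM.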

Compound 4, concentration for total growth inhibition: 9350 nM
Estimate against measurement, compound 4: 4.7-fold (0.67 log units) below; measured number above the stated range.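

In this assay, the change from benzyl to methyl lowers the number on the second core as well, a 6.3-fold lower number from compound 2 to compound 4 (0.80 log units; beyond the scatter), so the direction of the step carries over in the two cases shown. The size of the step does not carry over, and the two steps differ: the same change on two cores in this assay, a 39-fold lower number (1.59 log units; beyond the scatter) from compound 3 to compound 1 and a 6.3-fold lower number (0.80 log units; beyond the scatter) from compound 2 to compound 4, 6.1-fold (0.79 log units) apart, beyond the scatter of two such steps

Among the compounds shown here, with only two cores, this does not show why the step is smaller on the core of compound 2, nor how the change would behave on any further core.

The compounds shown leave open how a longer chain, such as ethyl, would read in place of the methyl. They also leave open whether a substituted benzyl, such as one carrying an amine on its phenyl, would keep the high numbers of compound 2 and compound 3.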